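One Substituent Swap on the Amide Nitrogen

This account rests on a few compounds, and the source may have more. Where it says the series, first, only, none or still open, it means among the compounds named here.

Two measured compounds share one core and differ only in the aromatic group attached to an amide-type nitrogen. In a functional assay on SF-295 cells (Homo sapiens) for inhibition, read by sulforhodamine B assay, with a stated time of 48 h, tested at 0.1 uM (on this read-out lower numbers stand for a stronger effect and higher numbers for a weaker effect at the one concentration tested), compound 1 `COc1cc(Cl)cc(-c2nn(-c3cccc(NC(=O)Nc4cc(C(F)(F)F)cc(C(F)(F)F)c4)c3)cc2-c2ccncc2)c1` gives 91%. Compound 2 `COc1cc(Cl)cc(-c2nn(-c3cccc(NC(=O)Nc4ccc(Cl)c(Cl)c4)c3)cc2-c2ccncc2)c1` gives 57% in this assay. Compound 2 therefore stands at the lower of the two numbers, meaning the stronger effect, and its gap to compound 1 lies beyond the usual scatter.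

Compound 3 `COc1cc(Cl)cc(-c2nn(-c3cccc(NC(=O)Nc4cccc(C(F)(F)F)c4)c3)cc2-c2ccncc2)c1` has not been measured yet. It differs from compound 2 in a single place: 3-(trifluoromethyl)phenyl in place of 3,4-dichlorophenyl on an amide-type nitrogen. The entering group sits on the same amide-type nitrogen whose other neighbour is the carbonyl carbon.

Among the compounds with values here, no measured pair shows exactly this change, so the expectation rests on the two numbers at hand. Compound 1, which also carries trifluoromethyl on the aromatic ring at this nitrogen, gives 91%, well above compound 2. For compound 3 the expected step is a number 15 percentage points higher from compound 2 to compound 3 (beyond the scatter), an upward move toward a weaker effect that may just reach beyond the scatter. Compound 3 is estimated at 72%, with a likely range from 52% to 92%.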

Compound 3, a percentage reported as activity, at one concentration (the size of the read-out at that concentration, not a potency): 57%
Beside the measured number, compound 3's estimate is 15 percentage points above it; the measured number falls inside the stated range.
By their numbers in this assay, from the lowest: compounds 2 and 3 (each within the scatter of the next); then compound 1.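

In this assay, putting 3-(trifluoromethyl)phenyl in place of 3,4-dichlorophenyl on the amide-type nitrogen gives no change at the digits printed from compound 2 to compound 3 (within the scatter), so at this position the two groups cannot be told apart by this read-out, even though they differ in their atoms. Placing hydrogen in place of trifluoromethyl on an aromatic carbon gives a number 34 percentage points lower from compound 1 to compound 3 (beyond the scatter), a move toward a stronger effect, which shows that the weak result of compound 1 goes with its extra trifluoromethyl and not with the presence of trifluoromethyl on this ring as such. Nothing available here explains either step, so the numbers describe what happens at this position but not why.

The compounds shown leave open how a plain phenyl ring, or a ring carrying a single chlorine, a methoxy group or a nitrile, would behave on this nitrogen. They also leave open whether compound 2 and compound 3 would still match at other concentrations, since each number here comes from a single concentration and is not a potency.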